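The source may report more compounds than this note shows. Statements on the series, on what has been measured and on what is new or still open speak of the compounds shown alone.

Among the measured compounds shown here, in an assay on brain for displacement of a labelled ligand from Adrenergic receptor alpha-1 (Rattus norvegicus) (a lower number here means a stronger inhibitor, a higher number a weaker inhibitor), compound 2 `CCOC(C)COC1CCN(c2nc(N)c3cc(OC)c(OC)cc3n2)CC1` gives 0.99 nM; the only other number, that of compound 1 `COc1cc2nc(N3CCC(OCC(C)OC)CC3)nc(N)c2cc1OC`, is 1.41 nM, and the step of a 1.4-fold lower number from compound 1 to compound 2 (0.15 log units; within the scatter) separates them only within the scatter. Compound 3 `COc1cc2nc(N3CCC(OCC(C)O)CC3)nc(N)c2cc1OC` differs from compound 2 by hydrogen in place of ethyl on an oxygen on a saturated carbon, which read one bond further out is ethoxy to hydroxy. For the measured compounds named here, no measured step removes an ethyl from this oxygen; the single step at hand, a methyl entering a chain carbon, stayed within the scatter, so no move beyond the scatter in this assay is expected here either. For compound 3 the expected value is 1.5 nM, with a range of 0.5 nM to 4.5 nM, amounting to an estimated step of a 1.5-fold higher number from compound 2 to compound 3 (0.18 log units; within the scatter).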

Compound 3, inhibition constant: 3.52 nM
Compound 3: middle estimate off by 2.3-fold (0.37 log units), on the low side, and the stated range covers the measured number.
By their numbers in this assay, from the lowest: compounds 2 and 1 (each within the scatter of the next); then compound 3.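

In this assay, among the compounds shown here, the oxygen on a saturated carbon is the first place where a change moves the number beyond the scatter: ethoxy to hydroxy gives a 3.6-fold higher number from compound 2 to compound 3 (0.55 log units; beyond the scatter), and methoxy to hydroxy gives a 2.5-fold higher number from compound 1 to compound 3 (0.40 log units; beyond the scatter). Both steps are modest and point the same way, whereas the methyl step on the chain carbon, a 1.4-fold lower number from compound 1 to compound 2 (0.15 log units; within the scatter), stayed within the scatter. Nothing available explains the rise.

Still open, going by these compounds, is whether a longer chain on this oxygen would keep the number near those of the two ethers. An amine in place of the hydroxy is equally untested by the compounds shown.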